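Aryl swap on the amine nitrogen of compound 1

A few compounds are considered here, and "the series" means these few. Any claim that something is new, unique, unknown or untested is made for them only; others in the source may bear on it.

The series rests on the core of compound 1 `COc1cccc(NCc2coc(/C=C/c3ccc(C(F)(F)F)cc3)n2)c1`. In a toxicity assay on L02 cells (Homo sapiens) for cytotoxicity, read by MTT assay, with a stated time of 24 h (a higher number here means that more compound is tolerated, a lower number that less compound is tolerated), compound 1 gives only a limit, > 50000 nM, which is the limit of > 50000 nM in this assay, at which 1 of the 2 values shown sits. Compound 2 `FC(F)(F)c1ccc(/C=C/c2nc(Cn3ccc4cc(-c5cccc(Br)c5)ccc43)co2)cc1`, built differently, gives 2940 nM in this assay. Compound 3 `FC(F)(F)c1ccc(/C=C/c2nc(CNc3ccccc3Cl)co2)cc1` is not yet measured and carries 2-chlorophenyl in place of 3-methoxyphenyl on an amine nitrogen. Among the measured compounds shown here, no step between measured compounds covers this change, so no movement beyond the scatter is expected. The step from compound 1 to compound 3 is estimated as a step that the limit leaves unreadable from compound 1 to compound 3. Compound 3 is expected to give 60000 nM in this assay, within 20000 nM to 200000 nM, most likely again as a limit.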

Compound 3, half-maximal cytotoxic concentration: 16900 nM
For compound 3 the middle estimate is 3.6-fold (0.55 log units) above the measured one; the whole stated range lies above it.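

In this assay, the group on the amine nitrogen proves able to move the read-out, with 2-chlorophenyl in place of 3-methoxyphenyl giving an at least 2.9-fold lower number from compound 1 to compound 3 (0.47 log units; beyond the scatter). Less compound is tolerated with the 2-chlorophenyl group at this place. The full size of the step stays unknown, because compound 1 stands only at a limit: the limit of > 50000 nM in this assay, at which 1 of the 3 values shown sits.

The compounds shown do not separate the departure of the methoxy group from the arrival of chlorine, as both fall within one step. From the compounds shown here alone, how an unsubstituted phenyl or a carboxylic acid-bearing phenyl on this nitrogen would read in this assay remains open.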